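A few compounds are considered here, and "the series" means these few. Any claim that something is new, unique, unknown or untested is made for them only; others in the source may bear on it.

Measured in a functional assay on HT-29 cells (Homo sapiens) for inhibition, read by MTT assay, with a stated time of 96 h; a higher number here means a weaker inhibitor of growth, a lower number a stronger inhibitor of growth:
- compound 1 `O=C(NCCCCCCSSCCCCCCNC(=O)c1cc(-c2ccncc2)n[nH]1)c1cc(-c2ccncc2)n[nH]1`: 6920 nM
- compound 2 `C=CCOC(=O)SCCCCCCNC(=O)c1cc(-c2ccncc2)n[nH]1`: 11900 nM
- compound 3 `CCCCCCCC/C=C\CCCCCCCC(=O)SCCCCCCNC(=O)c1cc(-c2ccncc2)n[nH]1`: 23500 nM

At 11900 nM, compound 2 lies within the scatter of both compound 1 and compound 3. The next compound to test, compound 4 `CC(=O)SCCCCCCNC(=O)c1cc(-c2ccncc2)n[nH]1`, has methyl in place of allyloxy on a carbonyl carbon.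

Within the data shown here, no measured pair differs in one place only, which leaves no direct precedent for this change. The expectation therefore rests on the narrow spread of values, with compound 1 at 6920 nM and compound 3 at 23500 nM. The expected 1.2-fold lower number from compound 2 to compound 4 (0.08 log units; within the scatter) stays within the scatter, with no direction favoured. For compound 4 the estimated value in this assay is 10000 nM, with an expected range of 4500 nM to 22000 nM.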

Compound 4, concentration for 50% growth inhibition: 23100 nM
Compound 4: middle estimate off by 2.3-fold (0.36 log units), on the low side, and the stated range ends below it.
By their numbers in this assay, from the lowest: compounds 1, 2, 4 and 3 (each within the scatter of the next, the first and the last beyond it).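

The change of methyl in place of allyloxy on a carbonyl carbon gives the series its first one-place comparison: in this assay it produces a 1.9-fold higher number from compound 2 to compound 4 (0.29 log units; within the scatter). On a carbonyl carbon whose other neighbour is sulfur, removing allyloxy therefore leaves the number within the scatter, although this rests on a single step. Nothing measured here bears on a cause for this step.

On these data alone, whether an amine or a phenyl group on this carbonyl carbon would take the number beyond the scatter remains open. So does the effect of a longer chain in place of the hexyl linker.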